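The source may report more compounds than this note shows. Statements on the series, on what has been measured and on what is new or still open speak of the compounds shown alone.

Three analogues built on the shared core have numbers in a functional assay on JAR cells (Homo sapiens) for inhibition, read by MTT assay, with a stated time of 72 h, tested at 10 uM; on this read-out lower numbers stand for less inhibition and higher numbers for more inhibition at the one concentration tested (going by the name of the read-out). Compound 1 `CCOC(=O)C1=C(Nc2ccccc2)S/C(=C\c2ccc(O)c(O)c2)C1=O` gives 48.7% in this assay. Compound 2 `CCOC(=O)C1=C(Nc2ccccc2)S/C(=C\c2cc(OC)ccc2OC)C1=O` gives 38.1% in this assay, and compound 3 `CCOC(=O)C1=C(Nc2ccc([N+](=O)[O-])cc2)S/C(=C\c2ccc[nH]2)C1=O` gives 54.9% there. Compound 1 stands second highest of the three numbers; its nearest neighbour is compound 3, whose number lies within the scatter of it, while compound 2 lies beyond the scatter and lower. No pair among these three differs in only one place, so no single step can be read from them, and the numbers as a whole fall within a narrow band.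

Compound 4 `CCOC(=O)C1=C(Nc2ccccc2)S/C(=C\c2cc3ccncc3[nH]2)C1=O` is not yet measured in this assay. It differs from compound 1 by a group of 9 heavy atoms (7 carbon, 2 nitrogen; one five-membered aromatic ring with 1 hetero atom, one six-membered aromatic ring with 1 hetero atom) in place of a group of 8 heavy atoms (6 carbon, 2 oxygen; one six-membered aromatic ring of carbon only), on a double-bonded chain carbon bound to a double-bonded ring carbon. Among the measured compounds shown here, with the measured numbers clustered and no step of this kind on record, the step is expected to be small, of uncertain direction and probably not beyond the scatter, estimated as a number 3.7 percentage points lower from compound 1 to compound 4 (within the scatter). Compound 4 is therefore estimated at 45% in this assay, with a range from 30% to 62%.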

Compound 4, a percentage reported as inhibition, at one concentration (the size of the read-out at that concentration, not a potency): 26.3%
Compound 4: the middle estimate sits 18.7 percentage points above what was measured, outside the stated range (below it).
By their numbers in this assay, from the lowest: compound 4; then compound 2; then compounds 1 and 3 (each within the scatter of the next).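

Among the compounds shown here, replacing 3,4-dihydroxyphenyl with the group of one five-membered and one six-membered aromatic ring, on a double-bonded chain carbon bound to a double-bonded ring carbon, gives the only readable step in this assay (a number 22.4 percentage points lower from compound 1 to compound 4 (beyond the scatter)). For the compounds shown here, this place on the shared core is therefore not indifferent to the group it carries, which the earlier compounds, with no pair differing in one place, could not show. Nothing available accounts for the step.

The exchange alters the whole group at once, so the share of the two hydroxyl groups and of the ring nitrogens in the step remains unresolved. Simpler groups at this place, such as an unsubstituted phenyl or a 4-hydroxyphenyl, would separate those contributions, and whether the step holds with a morpholine in place of the anilino group also stays open.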